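Methoxy on the phenyl ring of a hydrazone series

The source may hold more compounds than are shown below. What is called first, only, known or untested is meant among the compounds shown, and "the series" means these compounds.

Among the compounds with values here, compound 2 `Cc1csc(N/N=C(/C=C/c2ccccc2)c2nc3ccccc3[nH]2)n1` is one of two compounds measured in an ADME assay on MDCK cells (Canis lupus familiaris) for cytotoxicity, read by CCK-8 assay, with a stated time of 72 h; a lower number here means a stronger inhibitor, a higher number a weaker inhibitor. In this assay compound 2 gives 2.9 ug/mL, and compound 1 `NC(=S)N/N=C(/C=C/c1ccccc1)c1nc2ccccc2[nH]1` gives 3.4 ug/mL. Within the data shown here, the only step among the measured compounds, a 1.2-fold lower number from compound 1 to compound 2 (0.07 log units; within the scatter), swaps the group on the amine nitrogen and lies within the scatter. Compound 2 thus holds the lower of the two numbers, but the gap to compound 1 is within the scatter, so no order between them can be claimed.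

Compound 3 `COc1ccc(/C=C/C(=N/Nc2nc(C)cs2)c2nc3ccccc3[nH]2)cc1` differs from compound 2 in one place: methoxy in place of hydrogen on an aromatic carbon. Among the measured compounds shown here, no measured step touches this ring, so no step bears directly on the change; the single known step at the amine nitrogen gave nothing beyond the scatter, and nothing in the data points to a larger effect here. Compound 3 is therefore expected to give a number close to that of compound 2, the expected step being a 1.0-fold higher number from compound 2 to compound 3 (0.01 log units; within the scatter). The estimate for compound 3 is 3 ug/mL, with a range from 1.5 ug/mL to 6 ug/mL.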

Compound 3, half-maximal inhibitory concentration: 1.9 ug/mL
Beside the measured number, compound 3's estimate is 1.6-fold (0.20 log units) above it; measured number inside the range.
By their numbers in this assay, from the lowest: compounds 3, 2 and 1 (each within the scatter of the next).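

Within the data shown here, the change from phenyl to 4-methoxyphenyl gives the first reading on this ring in this assay and amounts to a 1.5-fold lower number from compound 2 to compound 3 (0.18 log units; within the scatter), so methoxy on this aromatic carbon, para to a large group, moves the number no further than repeated measurements would. Until now the only step lay on the amine nitrogen, and this second step, at a different place in the structure, also stays within the scatter, so neither place has yet shown a change that can be read as real. The compounds shown offer no measured finding that would explain the size of this step.

With only hydrogen and methoxy seen on this carbon, the compounds shown leave open whether the position is insensitive in general or merely to this one group; an amine, a carboxylic acid, chlorine or a longer chain such as butoxy could still carry the number beyond the scatter. They also leave open whether methoxy elsewhere on the ring would read the same, and whether the same change would give a similar step with the group on the amine nitrogen of compound 1.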